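Compound 2 to compound 4: dimethylamino on the core

A few compounds are considered here, and "the series" means these few. Any claim that something is new, unique, unknown or untested is made for them only; others in the source may bear on it.

In an ADME assay on cells (Homo sapiens) for cytotoxicity, read by polymerase chain reaction, with a stated time of 3 days (a lower number here means that less compound is tolerated, a higher number that more compound is tolerated), compound 1 (`Nc1nc(Cl)c(-c2cc3ccccc3s2)c(N[C@@H]2C[C@H](CO)[C@@H](O)[C@H]2O)n1`) gives > 25000 nM as its reading, which is a limit of the assay and not a number. Compound 2 (`Nc1nc(Cl)c(-c2nc3ccccc3s2)c(N[C@@H]2C[C@H](CO)[C@@H](O)[C@H]2O)n1`) gives 14000 nM and compound 3 (`CNc1ccc2sc(-c3c(Cl)nc(N)nc3N[C@@H]3C[C@H](CO)[C@@H](O)[C@H]3O)nc2c1`) gives 20000 nM in the same assay. These two numbers lie within the scatter of each other, so compound 2 is not separated from compound 3.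

The change to compound 4 (`CN(C)c1ccc2nc(-c3c(Cl)nc(N)nc3N[C@@H]3C[C@H](CO)[C@@H](O)[C@H]3O)sc2c1`) is dimethylamino in place of hydrogen on an aromatic carbon on a six-membered aromatic ring of carbon only: dimethylamino in place of hydrogen on an aromatic carbon. The closest measured step is methylamino in place of hydrogen, a 1.4-fold higher number from compound 2 to compound 3 (0.15 log units; within the scatter) and it is the main guide here. The step of an at least 1.7-fold lower number from compound 1 to compound 2 (0.25 log units; that floor lies within the scatter) exchanges a different group and bears on this change only loosely.

Since the methylamino group of compound 3 leaves it at 20000 nM no step beyond the scatter is expected in this assay for the dimethylamino group. The expected size is a 1.2-fold higher number from compound 2 to compound 4 (0.08 log units; within the scatter) and no more than that is claimed. For compound 4 the estimated value is 17000 nM with an expected range from 9000 nM to 25000 nM in this measurement.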

Compound 4, half-maximal cytotoxic concentration: > 25000 nM
Compound 4: a limit, no number; the forecaster's own chance of this, stated with the estimate: 15%; middle value at least 1.4-fold (0.16 log units) from the limit.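

In this assay compound 4 gives > 25000 nM, which is a limit and not a number. Dimethylamino in place of hydrogen on this carbon of the six-membered aromatic ring gives an at least 1.7-fold higher number from compound 2 to compound 4 (0.25 log units; that floor lies within the scatter), so the printed floor does not separate the two compounds, and the first reading of this group on the core shows no measured drop in the concentration tolerated. The true size of the step cannot be read because the reading of compound 4 stops at the ceiling of the measurement: the limit of > 25000 nM in this assay, at which 2 of the 4 values shown sit.

Still open, from the compounds shown here alone, is whether a carboxylic acid or a longer chain ending in an amine on this same carbon would give a reading below the limit. Also open, going by these compounds, is whether a cyclic amine such as morpholine would behave like dimethylamino here.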